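Branching the hydroxy acid side chain of a naphthoquinone ester

The compounds below may be only part of what the source reports. "The series", "measured", "known", "first", "only" and "open" are said of these compounds alone.

Compound 1, `CCCC(O)CC(=O)O[C@H](CC=C(C)C)C1=CC(=O)c2c(O)ccc(O)c2C1=O`, in a functional assay on DU-145 cells (Homo sapiens) for cytotoxicity, read by MTT assay (a higher number here means a weaker inhibitor, a lower number a stronger inhibitor), gives > 100000 nM, which is a limit of the assay and not a number.
Compound 2, `CC[C@](C)(O)CC(=O)O[C@H](CC=C(C)C)C1=CC(=O)c2c(O)ccc(O)c2C1=O`, in this assay gives 20500 nM.
Compound 3, `CCCCCCC(C)(O)CC(=O)O[C@H](CC=C(C)C)C1=CC(=O)c2c(O)ccc(O)c2C1=O`, in this assay gives > 100000 nM, again a limit and not a number.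

Compound 1 therefore stands at the weak edge of what has been measured, at the limit of > 100000 nM in this assay, at which 2 of the 3 values shown sit. The step under study leads to compound 4, `CC(C)=CC[C@@H](OC(=O)CC(C)(O)C(C)C)C1=CC(=O)c2c(O)ccc(O)c2C1=O`, and the change is 1-hydroxy-1,2-dimethylpropyl in place of 1-hydroxybutyl on a saturated chain carbon bound to a carbonyl carbon. Among the compounds with values here, two measured steps bear on it. The step of an at least 4.8-fold lower number from compound 1 to compound 2 (0.68 log units; beyond the scatter) shows that a short chain with the hydroxyl on a carbon that also carries a methyl brings the number down. The step of an at least 4.8-fold higher number from compound 2 to compound 3 (0.68 log units; beyond the scatter) shows that lengthening that chain loses the gain, and the step that the two limits leave unreadable from compound 1 to compound 3. The 1-hydroxy-1,2-dimethylpropyl of compound 4 is closer in size to the 1-hydroxy-1-methylpropyl of compound 2 than to the 1-hydroxy-1-methylheptyl of compound 3, so a modest drop is expected, though compound 4 might also only reach the limit. For compound 4 the expected step is an at least 2.8-fold lower number from compound 1 to compound 4 (0.45 log units; beyond the scatter). Compound 4 is estimated at 35000 nM, between 12000 nM and 100000 nM.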

Compound 4, half-maximal inhibitory concentration: 16900 nM
Compound 4: the middle estimate sits 2.1-fold (0.32 log units) above what was measured, within the range that was stated.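

In this assay, compound 4 gives a second short side chain with a readable value: 1-hydroxy-1,2-dimethylpropyl in place of 1-hydroxybutyl gives an at least 5.9-fold lower number from compound 1 to compound 4 (0.77 log units; beyond the scatter), and isopropyl in place of hexyl gives an at least 5.9-fold lower number from compound 3 to compound 4 (0.77 log units; beyond the scatter). The branched isopropyl end does not alter what compound 2 already reached, since the step of a 1.2-fold lower number from compound 2 to compound 4 (0.08 log units; within the scatter) leaves the two compounds level, so at this position on a saturated chain carbon bound to a carbonyl carbon, the 1-hydroxy-1-methylpropyl and 1-hydroxy-1,2-dimethylpropyl groups cannot be told apart in this assay, while the longer 1-hydroxy-1-methylheptyl of compound 3 goes against any gain from the methyl alone. Compound 1 and compound 3 each enter these steps as a limit of the assay and not as a number, so both steps give only a minimum size: the limit of > 100000 nM in this assay, at which 2 of the 4 values shown sit.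

The compounds shown leave open how long the chain can grow before the readable value is lost, as a butyl or pentyl end in place of the isopropyl would show. They also leave open whether a cyclopropyl ring, an amine or a carboxylic acid at that end would be tolerated.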